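The source may report more compounds than this note shows. Statements on the series, on what has been measured and on what is new or still open speak of the compounds shown alone.

Measured in a functional assay on Jurkat cells (Homo sapiens) for cytotoxicity, with a stated time of 72 h; a higher number here means that more compound is needed for the effect, a lower number that less compound is needed:
- Compound 1 `C=C[C@@](C)(/C=C/c1ccc(OS(=O)(=O)C(F)(F)F)cc1)CCC=C(C)C`: > 49000 nM, a limit
- Compound 2 `C=C[C@@](C)(/C=C/c1ccc(O)cc1)CCC=O`: > 49000 nM, a limit

Compound 2 stands at > 49000 nM, which is a limit and not a number. The data so far show only (the limit of > 49000 nM in this assay, at which 2 of the 2 values shown sit).

Compound 3 `C=C[C@@](C)(/C=C/c1ccc(O)cc1)CCCO` differs from compound 2 by one change: hydroxymethyl in place of formyl on a saturated chain carbon, three bonds along the chain from two double-bonded chain carbons. Among the measured compounds shown here, no measured step shows what this change does. With compound 2 at > 49000 nM, no shift beyond the scatter is expected in this assay, in either direction. The expected change is a number no higher from compound 2 to compound 3 (the limit leaves the size open). For compound 3 the estimate is 49000 nM, with an expected range of 20000 nM to 100000 nM.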

Compound 3, half-maximal effective concentration: > 49000 nM
Compound 3 gave a limit, no number (the forecaster's own chance of this, stated with the estimate: 80%); the middle value sits exactly at the limit.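

Compound 2 and compound 3 both give only a limit, and no step can be read between them: the limit of > 49000 nM in this assay, at which 3 of the 3 values shown sit. The compounds shown leave open whether hydroxymethyl in place of formyl changes anything in this assay, and at what concentration any of them acts.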